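This account rests on a few compounds, and the source may have more. Where it says the series, first, only, none or still open, it means among the compounds named here.

Series notes. In a functional assay on PC-3 cells (Homo sapiens) for antiproliferative activity, read by MTT assay, tested at 5 uM (a higher number here means a stronger effect of the compound at the concentration tested, a lower number a weaker effect), compound 1 `COc1cc(C2=NN(C(C)=O)C(c3cc(Cl)cc(Cl)c3)O2)cc(OC)c1OC` gives 93.9%. In this assay compound 2 `COc1cc(C2=NN(C(C)=O)C(c3ccc(F)cc3)O2)cc(OC)c1OC` gives 0.1%, and compound 3 `COc1cc(C2=NN(C(C)=O)C(c3ccccc3F)O2)cc(OC)c1OC` gives 31.6%. Compound 3 therefore stands second highest of the three numbers: the step of a number 31.5 percentage points higher from compound 2 to compound 3 (beyond the scatter) is beyond the scatter, and the step of a number 62.3 percentage points lower from compound 1 to compound 3 (beyond the scatter) leaves compound 1 far above it.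

Compound 4 `COc1cc(C2=NN(C(C)=O)C(c3cccc(F)c3)O2)cc(OC)c1OC` differs from compound 3 in one place: 3-fluorophenyl in place of 2-fluorophenyl on a saturated ring carbon

Going by the values given here, three measured steps bear on this change. The steps of a number 93.8 percentage points lower from compound 1 to compound 2 (beyond the scatter) and a number 62.3 percentage points lower from compound 1 to compound 3 (beyond the scatter) show that the aryl group on the saturated ring carbon moves the read-out over almost its full range, and the step of a number 31.5 percentage points higher from compound 2 to compound 3 (beyond the scatter) shows that exchanging one fluorophenyl for another is by itself enough for a large shift. Among the compounds with values here, no measured pair contains a 3-fluorophenyl, so the direction for compound 4 can only be read from the two fluorophenyl compounds and from compound 1, whose 3,5-dichlorophenyl gives the highest number.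

On that basis a step upward beyond the scatter is expected for compound 4, namely a number 16.4 percentage points higher from compound 3 to compound 4 (beyond the scatter), though the uncertainty is wide. Compound 4 is estimated at 48%, within 8% to 88%.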

Compound 4, a percentage reported as inhibition, at one concentration (the size of the read-out at that concentration, not a potency): 43.5%
Estimate against measurement, compound 4: 4.5 percentage points above; the measured number falls inside the stated range.
By their numbers in this assay, from the lowest: compound 2; then compound 3; then compound 4; then compound 1.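

In this assay the three fluorophenyl groups on the saturated ring carbon can now be read together, and they separate beyond the scatter: a number 11.9 percentage points higher from compound 3 to compound 4 (beyond the scatter) and a number 43.4 percentage points higher from compound 2 to compound 4 (beyond the scatter) place 3-fluorophenyl highest of the three and 4-fluorophenyl lowest. Even the best of these fluorophenyl groups stays well short of 3,5-dichlorophenyl, with a number 50.4 percentage points lower from compound 1 to compound 4 (beyond the scatter) showing that moving one fluorine around the phenyl ring does not close the distance to compound 1. Nothing available here explains this order among the fluorophenyl groups.

The compounds shown leave open whether the gap to compound 1 follows from having chlorine instead of fluorine or from having two ring substituents instead of one, a question that a phenyl bearing a single chlorine or one bearing two fluorines would address. Also open, from the compounds shown here alone, is how this order holds up with an amine or a carboxylic acid on the phenyl ring, or with a longer acyl chain such as propionyl in place of the acetyl group, and whether the stronger and weaker effects seen at this one concentration would keep their order at other concentrations.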